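Compound 3 to compound 4: an aryl exchange

The compounds below may be only part of what the source reports. "The series", "measured", "known", "first", "only" and "open" are said of these compounds alone.

For the measured compounds named here, in a functional assay on A549 cells (Homo sapiens) for antiproliferative activity, read by MTT assay (on this read-out higher numbers stand for weaker inhibition and lower numbers for stronger inhibition), compound 3 `COc1cccc(/C=N/Nc2ncc3c(n2)n(C2CCCC2)c(=O)c(=O)n3C)c1` gives 27400 nM, the only actual number so far. Compound 1 `Cn1c(=O)c(=O)n(C2CCCC2)c2nc(N/N=C/c3ccccc3)ncc21` reports only a limit, > 100000 nM. Compound 2 `Cn1c(=O)c(=O)n(C2CCCC2)c2nc(N/N=C/c3ccc(O)cc3)ncc21` also reports only a limit, > 100000 nM. Compound 4 `Cn1c(=O)c(=O)n(C2CCCC2)c2nc(N/N=C/c3ccc(C(F)(F)F)cc3)ncc21` carries 4-(trifluoromethyl)phenyl in place of 3-methoxyphenyl on a carbon with a double bond to nitrogen. Going by the values given here, two measured steps bear on this change: an at least 3.6-fold lower number from compound 1 to compound 3 (0.56 log units; beyond the scatter) and an at least 3.6-fold lower number from compound 2 to compound 3 (0.56 log units; beyond the scatter). From the compounds shown here alone, both are open-ended, so their full size is unknown. Compound 4 has no methoxy group, so a partial return toward weaker inhibition is expected, namely a 1.8-fold higher number from compound 3 to compound 4 (0.26 log units; within the scatter). The estimate for compound 4 is 50000 nM, with an expected range of 15000 nM to 100000 nM.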

Compound 4, half-maximal inhibitory concentration: 40600 nM
Compound 4: middle estimate off by 1.2-fold (0.09 log units), on the high side; the range from low to high includes it.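

Compound 4 shows that a methoxy group is not needed for a measurable number at this position: the record gives an at least 2.4-fold lower number from compound 1 to compound 4 (0.39 log units; beyond the scatter) and an at least 2.4-fold lower number from compound 2 to compound 4 (0.39 log units; beyond the scatter). The exchange itself gives a 1.5-fold higher number from compound 3 to compound 4 (0.17 log units; within the scatter), so 3-methoxyphenyl and 4-(trifluoromethyl)phenyl cannot be told apart here. Both open-ended steps stay without a full size because compound 1 and compound 2 each rest on a limit rather than a number: the limit of > 100000 nM in this assay, at which 2 of the 4 values shown sit.

From the compounds shown here alone, whether an amine or a carboxylic acid on this aromatic ring would give a clearly lower number remains open.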